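The source may hold more compounds than are shown below. What is called first, only, known or untested is meant among the compounds shown, and "the series" means these compounds.

Compound 1 `Nc1cc(N)c2nc(-c3ccccc3)c(NCc3ccc(Cl)c(Cl)c3)nc2c1` carries a shared core with a benzylamine arm bearing two chlorines. In a functional assay on SF-268 cells (Homo sapiens) for inhibition, read by sulforhodamine B assay, with a stated time of 48 h (on this read-out higher numbers stand for lower toxicity in this test and lower numbers for higher toxicity in this test), compound 1 gives only a limit, < 100000 nM, not a number. Compound 2 `CCOC(=O)[C@H](CCC(=O)O)NC(=O)c1ccc(Sc2nc3cc(N)cc(N)c3nc2-c2ccccc2)cc1`, which carries a longer acidic side chain, also gives only a limit in this assay, < 100000 nM. Among the compounds with values here, compound 3 `COc1cc(CNc2nc3cc(N)cc(N)c3nc2-c2ccccc2)cc(OC)c1OC`, with three methoxy groups on its benzyl arm, is the one compound with a number, giving 49000 nM in this assay. Compound 1 therefore stands at the limit of < 100000 nM in this assay, at which 2 of the 3 values shown sit, so its true position relative to compound 3 cannot be read from what is shown.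

Compound 4 `Nc1cc(N)c2nc(-c3ccccc3)c(NCc3ccc(F)cc3)nc2c1` differs from compound 1 in one place: 4-fluorophenyl in place of 3,4-dichlorophenyl on a saturated chain carbon bound to a nitrogen on an aromatic ring. Within the data shown here, no measured pair of compounds shows what such a swap does in this assay, so the step from compound 1 to compound 4 is expected to stay close to the scatter, in either direction, with a step that the limit leaves unreadable from compound 1 to compound 4 as the expected step. On that basis compound 4 is estimated at 50000 nM in this assay, with a likely range from 15000 nM to 100000 nM.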

Compound 4, concentration lethal to 50% of the cells: 40700 nM
Estimate against measurement, compound 4: 1.2-fold (0.09 log units) above, within the range that was stated.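

No step can be read from compound 1 to compound 4, because compound 1 gives only a limit in this assay, not a number: the limit of < 100000 nM in this assay, at which 2 of the 4 values shown sit.

The compounds shown leave open whether 4-fluorophenyl in place of 3,4-dichlorophenyl raises, lowers or leaves unchanged the lethal concentration.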